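The compounds below may be only part of what the source reports. "The series", "measured", "known", "first", "only" and "open" are said of these compounds alone.

Four compounds share one question: what happens when the carboxylic acid on the shared core is turned into the corresponding amide. Compound 1 `O=C(O)c1ccc2ccc(C(=O)c3ccccc3)c-2cc1` and compound 2 `NC(=O)c1ccc2ccc(C(=O)c3ccccc3)c-2cc1` form the first such pair. The change between them is amino in place of hydroxy on a carbonyl carbon. In an assay on cells for displacement of a labelled ligand from Orexin/Hypocretin receptor type 1 (Homo sapiens), read by scintillation counting, with stated times of 10 min and 90 min, tested at 10 uM (a higher number here means more inhibition at the concentration tested (going by the name of the read-out), a lower number less inhibition), compound 1 gives 11%, and compound 2 gives 13.6%. The step of a number 2.6 percentage points higher from compound 1 to compound 2 (within the scatter) is therefore small, and the two readings cannot be told apart with confidence.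

Compound 3 `O=Cc1cc(-c2ccccc2)c2ccc(C(=O)O)ccc1-2` carries the same acid on a rearranged core; how its core differs from that of compound 1 is not broken down here. In this assay compound 3 gives 16.2%, a reading that sits within the scatter of both compound 1 and compound 2, so none of the three numbers can be called higher or lower than the others.

Compound 4 `NC(=O)c1ccc2c(C=O)cc(-c3ccccc3)c-2cc1` has not yet been measured. It relates to compound 3 exactly as compound 2 relates to compound 1: the change is amino in place of hydroxy on a carbonyl carbon, at the same place on the carbonyl carbon. Because the earlier step of a number 2.6 percentage points higher from compound 1 to compound 2 (within the scatter) was within the scatter, the step from compound 3 to compound 4 is expected to be similarly small, about a number 1.8 percentage points higher from compound 3 to compound 4 (within the scatter). On that basis, compound 4 is expected to give roughly 18% in this assay, most likely between 7% and 30%.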

Compound 4, a percentage reported as inhibition, at one concentration (the size of the read-out at that concentration, not a potency): 6.1%
Compound 4: the middle estimate sits 11.9 percentage points above what was measured, outside the stated range (below it).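

In this assay, putting amino in place of hydroxy on a carbonyl carbon, the swap of carboxy for carbamoyl, gives a number 10.1 percentage points lower from compound 3 to compound 4 (beyond the scatter), so on this core the change has a step that can be told apart from repeat-to-repeat noise. Setting this beside the same change on the other core does not show that the core alters the outcome: the same change on two cores in this assay, a number 2.6 percentage points higher (within the scatter) from compound 1 to compound 2 and a number 10.1 percentage points lower (beyond the scatter) from compound 3 to compound 4, 12.7 percentage points apart, within the scatter of two such steps. The pair of steps therefore neither proves that the change carries over unchanged from one core to the other nor proves that it does not, and since each number is the size of a read-out at a single concentration, neither step says anything about potency.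

The compounds shown leave open whether the step seen on the core of compound 3 would recur on a third core, since two pairs are too few to settle how far this change travels across the series. They also leave open how other groups in place of the carboxylic acid, such as a methyl ester, a nitrile or an N-methyl amide, would read on either core.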